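Replacing 1-Methylbutyl with 4-Hydroxybutyl: Cytotoxicity Outlook

The source may hold more compounds than are shown below. What is called first, only, known or untested is meant among the compounds shown, and "the series" means these compounds.

Compound 1 `CCCNc1cc(Oc2c(OC)cc3cc(C#N)ccc3c2OC)nc(Nc2ccc(C#N)cc2)n1`, compound 2 `CCC(CC)Nc1cc(Oc2c(OC)cc3cc(C#N)ccc3c2OC)nc(Nc2ccc(C#N)cc2)n1` and compound 3 `CCCC(C)Nc1cc(Oc2c(OC)cc3cc(C#N)ccc3c2OC)nc(Nc2ccc(C#N)cc2)n1` share one core and differ only in the group on a nitrogen on an aromatic ring. In an ADME assay on MT4 cells (Homo sapiens) for cytotoxicity, read by MTT assay, with a stated time of 5 days (on this read-out higher numbers stand for lower toxicity in this test and lower numbers for higher toxicity in this test), compound 1 gives a limit, > 125000 nM. In this assay compound 2 likewise gives a limit, > 125000 nM. In this assay compound 3 also gives a limit, > 125000 nM. Because of the limit of > 125000 nM in this assay, at which 3 of the 3 values shown sit, the steps a step that the two limits leave unreadable from compound 1 to compound 2, a step that the two limits leave unreadable from compound 1 to compound 3 and a step that the two limits leave unreadable from compound 2 to compound 3 cannot be sized. Compound 4 `COc1cc2cc(C#N)ccc2c(OC)c1Oc1cc(NCCCCO)nc(Nc2ccc(C#N)cc2)n1` differs from compound 3 by 4-hydroxybutyl in place of 1-methylbutyl on a nitrogen on an aromatic ring. Going by the values given here, no measured step reads on this change, so the expected step that the limit leaves unreadable from compound 3 to compound 4 in this assay is none beyond the scatter. Compound 4 is therefore estimated at 150000 nM in this assay, within 90000 nM to 300000 nM, most likely again reported as a limit.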

Compound 4, half-maximal cytotoxic concentration: 39100 nM
For compound 4 the middle estimate is 3.8-fold (0.58 log units) above the measured one, and the stated range ends above it.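

In this assay, going by these compounds alone, 4-hydroxybutyl on a nitrogen on an aromatic ring gives the first readable step at this position (an at least 3.1-fold lower number from compound 3 to compound 4 (0.50 log units; beyond the scatter)), and here the lower number stands for higher toxicity in this test. The reading is the same against the other two chains (an at least 3.1-fold lower number from compound 2 to compound 4 (0.50 log units; beyond the scatter)) and (an at least 3.1-fold lower number from compound 1 to compound 4 (0.50 log units; beyond the scatter)). These steps give only a minimum size, because of a limit: the limit of > 125000 nM in this assay, at which 3 of the 4 values shown sit.

On these data alone, whether an amine or a methyl ether in place of the hydroxyl would give a similar step stays open. So does the outcome for a longer chain carrying the hydroxyl.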